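A few compounds are considered here, and "the series" means these few. Any claim that something is new, unique, unknown or untested is made for them only; others in the source may bear on it.

Measured so far:
- compound 1 `O=c1ccc2cc(OCc3cc(-c4ccc5ccccc5c4)no3)ccc2o1`: 55900 nM
- compound 2 `O=c1ccc2cc(OCc3cn(-c4ccccc4)nn3)ccc2o1`: 51500 nM

Among the compounds with values here, in a functional assay on HCT-116 cells (Homo sapiens) for cytotoxicity, read by MTT assay, with a stated time of 48 h (on this read-out higher numbers stand for weaker inhibition and lower numbers for stronger inhibition), compound 2 gives 51500 nM, the lower of the two numbers measured so far; compound 1 gives 55900 nM, and the two values lie within the scatter of each other, so no order between them can be claimed. Within the data shown here, no step between the two measured compounds is computed, and the pair differs in more than one place.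

Compound 3 `O=c1ccc2cc(OCc3cn(-c4cccc([N+](=O)[O-])c4)nn3)ccc2o1` is not yet measured. It differs from compound 2 by nitro in place of hydrogen on an aromatic carbon, on an aromatic carbon of a six-membered aromatic ring of carbon only. Nothing measured in this series tests a change of this kind, so no step beyond the scatter is expected in this assay, in either direction. Compound 3 is therefore estimated at 45000 nM, between 15000 nM and 130000 nM, which is expected to mean a step of a 1.1-fold lower number from compound 2 to compound 3 (0.06 log units; within the scatter).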

Compound 3, half-maximal inhibitory concentration: 26900 nM
Compound 3: middle estimate off by 1.7-fold (0.22 log units), on the high side, and the stated range covers the measured number.
By their numbers in this assay, from the lowest: compounds 3, 2 and 1 (each within the scatter of the next, the first and the last beyond it).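

In this assay, the change from phenyl to 3-nitrophenyl, with nitro in place of hydrogen on an aromatic carbon, gives a 1.9-fold lower number from compound 2 to compound 3 (0.28 log units; within the scatter). Within the data shown here, this is the first reading at this position: three heavy atoms can be added to this six-membered aromatic ring of carbon only, meta to a large group, without a step beyond the scatter in either direction. No measured evidence bears on this result, so the step carries no explanation.

Going by these compounds, whether an amine or a carboxylic acid in the same place would give a step beyond the scatter remains open, as does the effect of nitro elsewhere on this ring. With a single step at a single position, no trend across groups on this ring can be stated.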